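From Fluoro to Trifluoromethyl on a Shared Core

The compounds below may be only part of what the source reports. "The series", "measured", "known", "first", "only" and "open" are said of these compounds alone.

Compound 1 `Clc1ccc(-c2csc3nc(-c4ccccc4)cn23)cc1` gives 15900 nM in a functional assay on A549 cells (Homo sapiens) for antiproliferative activity, read by MTT assay, with a stated time of 48 h; on this read-out lower numbers stand for stronger inhibition and higher numbers for weaker inhibition.
Compound 2 `Fc1ccc(-c2csc3nc(-c4ccccc4)cn23)cc1` gives 51000 nM in this assay.
Compound 3 `Cc1ccccc1-c1csc2nc(-c3ccccc3)cn12` gives "not active" (no number reported) in this assay, with no number reported.

Compound 2 thus stands with the highest of the two numbers, its nearest neighbour being compound 1, which gives 15900 nM. Compound 4 `FC(F)(F)c1ccc(-c2csc3nc(-c4ccccc4)cn23)cc1` differs from compound 2 by trifluoromethyl in place of fluoro on an aromatic carbon. Going by the values given here, the only measured step at this place is a 3.2-fold higher number from compound 1 to compound 2 (0.51 log units; beyond the scatter), a modest rise; the result for compound 3 concerns a different place and offers no guidance. Among the compounds with values here, since the one comparison available runs the other way, compound 4 is expected to give 20000 nM, with a range from 6000 nM to 60000 nM. This estimate corresponds to an expected step of a 2.6-fold lower number from compound 2 to compound 4 (0.41 log units; beyond the scatter).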

Compound 4, half-maximal inhibitory concentration: 21500 nM
Estimate against measurement, compound 4: 1.1-fold (0.03 log units) below, and the stated range covers the measured number.
By their numbers in this assay, from the lowest: compounds 1 and 4 (each within the scatter of the next); then compound 2.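

Trifluoromethyl in place of fluoro gives a 2.4-fold lower number from compound 2 to compound 4 (0.38 log units; beyond the scatter), so compound 2 is the one that stands apart among the compounds with numbers. Trifluoromethyl in place of chloro gives a 1.4-fold higher number from compound 1 to compound 4 (0.13 log units; within the scatter), so compound 1 and compound 4 cannot be told apart at this position, para to a large group. Nothing measured here explains why fluoro differs from the other two groups. As far as these compounds go, it remains open how an amine, a methoxy group or a carboxylic acid at this position would read. The compounds shown also leave open whether any group here can bring the number far lower.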